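The source may hold more compounds than are shown below. What is called first, only, known or untested is meant among the compounds shown, and "the series" means these compounds.

Working notes on the series. Among the compounds with values here, in an assay on isolated protein for activation of cGMP-dependent protein kinase 1 (Homo sapiens), read by ADP-Glo, with stated times of 120 min and 40 min (on this read-out higher numbers stand for an effect only at larger amounts of compound and lower numbers for an effect already at smaller amounts), compound 2 `O=C(O)c1cncc(CN2CCC[C@H](OCc3cc(Cl)cc(Cl)c3)[C@@H]2c2ccccc2)c1` gives 117000 nM, the only number recorded so far. Compound 1 `Clc1cc(Cl)cc(CO[C@H]2CCCN(Cc3ccccc3)[C@H]2c2ccccc2)c1` gives only a limit in this assay, > 200000 nM. On these data alone, the change from compound 1 to compound 2 reads as an at least 1.7-fold lower number from compound 1 to compound 2 (0.23 log units; that floor lies within the scatter); since one end rests on (the limit of > 200000 nM in this assay, at which 1 of the 2 values shown sits), the true size of that step stays open.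

Compound 3 `Clc1cc(Cl)cc(CO[C@H]2CCCN(Cc3ncc[nH]3)[C@H]2c2ccccc2)c1` differs from compound 2 by 1H-imidazol-2-yl in place of 5-carboxypyridin-3-yl on a saturated chain carbon bound to an amine nitrogen in a ring. Within the data shown here, the one measured step that touches the same position is an at least 1.7-fold lower number from compound 1 to compound 2 (0.23 log units; that floor lies within the scatter), and with its floor inside the scatter it offers no direction for a further exchange of the group on this carbon. Compound 3 is therefore expected to sit within the scatter of compound 2, a step of a 1.4-fold higher number from compound 2 to compound 3 (0.14 log units; within the scatter). The limit at which compound 1 sits also makes it plausible that this assay reports only a limit for compound 3. The estimate for compound 3 in this assay is 160000 nM, with a range from 60000 nM to 400000 nM.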

Compound 3, half-maximal effective concentration: 47000 nM
The estimate for compound 3 lay 3.4-fold (0.53 log units) above the measured number; the measured number lies below the stated range.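

At this position, on a saturated chain carbon bound to an amine nitrogen in a ring, the group now has a readable effect in this assay: 1H-imidazol-2-yl in place of 5-carboxypyridin-3-yl gives a 2.5-fold lower number from compound 2 to compound 3 (0.40 log units; beyond the scatter). The entering group is the smaller one, a five-membered aromatic ring of 5 heavy atoms against a six-membered aromatic ring of 9, so at this position the larger group bearing the carboxylic acid is not needed for the lower number within these compounds. Against phenyl, the exchange gives an at least 4.2-fold lower number from compound 1 to compound 3 (0.62 log units; beyond the scatter), a floor that lies beyond the scatter, but the full size of this step stays unknown because one end of it is a limit: the limit of > 200000 nM in this assay, at which 1 of the 3 values shown sits.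

The exchange from compound 2 to compound 3 alters ring size, ring hetero atoms and the carboxylic acid together, so the compounds shown cannot assign the step to any one of these, and a pyridine ring without the carboxylic acid or a methyl-substituted imidazole would separate them. On these data alone, it also stays open whether the step holds with other groups on the shared core, such as a replacement for the two chlorine atoms.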